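Side chain variation at the amide-bearing carbon

A few compounds are considered here, and "the series" means these few. Any claim that something is new, unique, unknown or untested is made for them only; others in the source may bear on it.

The series shares one core. Compound 1 `O=C(CN(c1ncnc2c1ncn2C1CCCCO1)C1CC1)N[C@@H](CO)C(=O)OCc1ccccc1` carries hydroxymethyl on the saturated chain carbon bound to an amide-type nitrogen and a carbonyl carbon, and compound 2 `CC[C@H](C)[C@H](NC(=O)CN(c1ncnc2c1ncn2C1CCCCO1)C1CC1)C(=O)OCc1ccccc1` carries sec-butyl there. In a functional assay on the whole organism (Tail, strain ICR) with Mus musculus as the target, in the tail flick test, with a stated time of 30 min, at a dose of 25 umol/kg by the oral route (a higher number here means a stronger effect of the compound at the dose given, a lower number a weaker effect), compound 1 gives 27.8%. For the measured compounds named here, compound 2 gives 25.6%; it stands as the lower of the two numbers so far, but its only neighbour is compound 1 and the step of a number 2.2 percentage points lower from compound 1 to compound 2 (within the scatter) lies within the scatter, so the two read as alike.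

Compound 3 `CSCC[C@H](NC(=O)CN(c1ncnc2c1ncn2C1CCCCO1)C1CC1)C(=O)OCc1ccccc1` is the next member: 2-(methylsulfanyl)ethyl in place of sec-butyl on a saturated chain carbon bound to an amide-type nitrogen and a carbonyl carbon. Going by the values given here, the one measured step at this place, a number 2.2 percentage points lower from compound 1 to compound 2 (within the scatter), exchanged one side chain for another and produced no movement beyond the scatter; nothing measured speaks to a chain carrying sulfur. The expectation for a number 0.4 percentage points higher from compound 2 to compound 3 (within the scatter) is therefore a step of no size beyond the scatter, in no preferred direction. Compound 3 is expected to give 26%, within 14% to 38%.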

Compound 3, a percentage reported as activity, at one dose (the size of the read-out at that dose, not a potency): 30%
For compound 3 the middle estimate is 4 percentage points below the measured one; the measured number falls inside the stated range.
By their numbers in this assay, from the lowest: compounds 2, 1 and 3 (each within the scatter of the next).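

In this assay a chain carrying sulfur now stands at the saturated chain carbon bound to an amide-type nitrogen and a carbonyl carbon, and the step of a number 4.4 percentage points higher from compound 2 to compound 3 (within the scatter) lies within the scatter, as does the step of a number 2.2 percentage points higher from compound 1 to compound 3 (within the scatter) on the comparison with the hydroxymethyl compound. 2-(Methylsulfanyl)ethyl, which brings sulfur and a hydrogen-bond acceptor, therefore reads as alike with sec-butyl, which has neither, so at this dose and time the three side chains shown are not separated by the read-out, and sulfur in the chain leaves no mark beyond the scatter. No measurement offered here bears on why these side chains read as alike.

Open, on these data alone, is whether an amine or a carboxylic acid at the end of this side chain, a phenyl ring on it, or a chain longer than 2-(methylsulfanyl)ethyl would give a step beyond the scatter. Also open, as far as these compounds go, is whether the likeness of compound 1, compound 2 and compound 3 would hold at other doses or at other times after dosing.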